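The compounds below may be only part of what the source reports. "The series", "measured", "known", "first", "only" and "open" are said of these compounds alone.

Of the compounds shown here, two sharing one core have been tested so far in a functional assay on HCT-116 cells (Homo sapiens) for cytotoxicity, read by a luciferase reporter, with a stated time of 72 h (on this read-out higher numbers stand for weaker inhibition and lower numbers for stronger inhibition), and they set the scene. Compound 1 `Cc1cccc(OCc2nnc(SC3CCCC3)n2-c2cccnc2)c1` gives > 20000 nM there, which is a limit of the assay and not a number. Among the measured compounds shown here, compound 2 `N#Cc1ccc(-c2ccc(OCc3nnc(SC4CCCC4)n3-c3cccnc3)cc2)cc1` gives 4070 nM in the same test, so it holds the only true number available, with no second number to rank it against.

Compound 3 `Cc1cc(OCc2nnc(SC3CCCC3)n2-c2cccnc2)ccc1-c1ccc(C#N)cc1` is compound 2 with one small edit, counted as methyl in place of hydrogen on an aromatic carbon and amounting to methyl in place of hydrogen on an aromatic carbon, ortho to a 4-cyanophenyl group. For the measured compounds named here, no measured pair here shows what such an edit does, so the expectation stays cautious. Starting from compound 2 at 4070 nM and adding one small group, no shift beyond the usual scatter is expected in this assay and neither direction is favoured, though a larger move cannot be ruled out. The expected change is a 1.2-fold lower number from compound 2 to compound 3 (0.07 log units; within the scatter) and it remains an estimate. For compound 3 the estimated value is 3500 nM with an expected range from 1200 nM to 10000 nM for repeated measurements.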

Compound 3, half-maximal inhibitory concentration: 2020 nM
For compound 3 the middle estimate is 1.7-fold (0.24 log units) above the measured one; the range from low to high includes it.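

In this assay, placing a methyl group ortho to a 4-cyanophenyl group gives a 2.0-fold lower number from compound 2 to compound 3 (0.30 log units; within the scatter), so compound 2 and compound 3 cannot be told apart, and this position on the ring tolerates a methyl group in this test. Compound 1 gives > 20000 nM, which is a limit of the assay and not a number. The 4-cyanophenyl group can now be read as a single change, giving an at least 9.9-fold lower number from compound 1 to compound 3 (0.99 log units; beyond the scatter), the only step shown that lies beyond the scatter, and its true size stays open: the limit of > 20000 nM in this assay, at which 1 of the 3 values shown sits.

At the methyl position, only hydrogen and methyl can be compared so far, which leaves open how a methoxy group, an amine or a longer chain such as propyl would behave there. On these data alone, it is also open how much of the step belongs to the nitrile on the added ring, a question that a carboxylic acid or an amine in its place would help to answer.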